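The compounds below may be only part of what the source reports. "The series", "measured", "known", "first", "only" and "open" are said of these compounds alone.

Of the compounds shown here, three of one series have been tested in a toxicity assay on THP-1 cells (Homo sapiens) for inhibition; on this read-out higher numbers stand for lower toxicity in this test and lower numbers for higher toxicity in this test. Compound 1 `Cn1c(-c2ccc(C#N)cc2)cnc1NC(=O)c1ncc[nH]1` gives > 100000 nM, which is a limit of the assay. Compound 2 `Cn1c(-c2ccc(C#N)cc2)cnc1NC(=O)c1ccc(F)cc1` gives > 50000 nM, likewise a limit. Compound 3 `Cn1c(-c2ccccc2)cnc1NC(=O)c1ccccc1` gives > 100000 nM, again a limit. For the measured compounds named here, the single measured step, a step that the two limits leave unreadable from compound 1 to compound 2, cannot be read in size because the limit of > 100000 nM in this assay, at which 2 of the 3 values shown sit, and the limit of > 50000 nM in this assay, at which 1 of the 3 values shown sits, both sit at limits rather than at numbers. Compound 2 thus stands at a limit, and no numerical value exists for it to compare against.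

Compound 4 `COc1cccc(-c2cnc(NC(=O)c3ccc(F)cc3)n2C)c1` differs from compound 2 in that (3-methoxyphenyl in place of 4-cyanophenyl on an aromatic carbon). Going by the values given here, no measured step touches this part of the structure, and the one step that was measured is unreadable, so the evidence offers no direction. The expected step is a step that the limit leaves unreadable from compound 2 to compound 4, not beyond the scatter. Compound 4 is estimated at 80000 nM, between 30000 nM and 200000 nM, and most likely the assay will again report only a limit.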

Compound 4, half-maximal cytotoxic concentration: > 100000 nM
Compound 4: a limit, no number; the forecaster's own chance of this, stated with the estimate: 75%; at least 1.2-fold (0.09 log units) between middle value and limit.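

In this assay compound 4 gives > 100000 nM, which is a limit of the assay. For the compounds shown here, compound 2 also stands at a limit, so no step between compound 2 and compound 4 can be read. The compounds shown leave open whether 3-methoxyphenyl in place of 4-cyanophenyl changes toxicity at all.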